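A few compounds are considered here, and "the series" means these few. Any claim that something is new, unique, unknown or untested is made for them only; others in the source may bear on it.

In a functional assay on GBM2 cells (Homo sapiens) for antiproliferative activity, read by WST assay, with a stated time of 72 h (a higher number here means a weaker inhibitor, a lower number a stronger inhibitor), three compounds on a shared core have been measured so far. Compound 1 (`O=C(Nc1ccc(C(F)(F)F)cc1)Nc1cc2ncncc2cc1OCc1cccc(F)c1`) gives 3200 nM in this test, compound 2 (`O=C(Nc1ccccc1F)Nc1cc2ncncc2cc1OCc1ccccc1`) gives 4500 nM in it, and compound 3 (`O=C(Nc1ccc(C(F)(F)F)cc1)Nc1cc2ncncc2cc1OCc1cccc(Cl)c1`) gives 4700 nM in it. Compound 3 therefore stands level with the other two, within the scatter of both.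

Compound 4 (`O=C(Nc1ccc(C(F)(F)F)cc1)Nc1cc2ncncc2cc1OCc1ccccc1`) departs from compound 3 in one place (hydrogen in place of chloro on an aromatic carbon), with hydrogen in place of chloro on an aromatic carbon, so that 3-chlorobenzyl becomes benzyl. Among the measured compounds shown here, the one measured step at this group is chloro in place of fluoro (a 1.5-fold higher number from compound 1 to compound 3 (0.17 log units; within the scatter)), and it stays within the scatter. Compound 2 also carries benzyloxy and gives 4500 nM but differs elsewhere as well, so it offers only loose support. No step beyond the scatter is therefore expected in this assay in either direction. The expected step is a 1.2-fold lower number from compound 3 to compound 4 (0.07 log units; within the scatter) as an estimate only. For compound 4 the estimated value is 4000 nM with an expected range from 1900 nM to 8500 nM in this test.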

Compound 4, half-maximal inhibitory concentration: 8600 nM
The estimate for compound 4 lay 2.2-fold (0.33 log units) below the measured number; measured number above the stated range.
By their numbers in this assay, from the lowest: compounds 1, 2, 3 and 4 (each within the scatter of the next, the first and the last beyond it).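

In this assay, among the compounds shown here, removing the fluoro group and leaving hydrogen gives a 2.7-fold higher number from compound 1 to compound 4 (0.43 log units; beyond the scatter) and is the first step at this position to pass the scatter, though only modestly, while hydrogen in place of chloro at the same place gives a 1.8-fold higher number from compound 3 to compound 4 (0.26 log units; within the scatter) and so does not separate compound 3 from compound 4. At the other end of the molecule, 4-(trifluoromethyl)phenyl in place of 2-fluorophenyl on an amide-type nitrogen gives a 1.9-fold higher number from compound 2 to compound 4 (0.28 log units; within the scatter) and leaves that exchange unresolved in this test. Nothing at hand explains why fluoro and chloro part from hydrogen to different degrees.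

The compounds shown leave open whether a methoxy group or an amine at this ring position would stand apart from fluoro, chloro and hydrogen. They also leave open whether the modest step seen with fluoro would hold with the 2-fluorophenyl group on the other side.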